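Distal ring swap and acid dissociation: working notes

The source may hold more compounds than are shown below. What is called first, only, known or untested is meant among the compounds shown, and "the series" means these compounds.

In a physicochemical assay for acid dissociation, compound 1 `COc1cccc(CNCCCNc2ccnc3cc(Cc4cc(C)cc(C)c4)ccc23)c1O` gives 9.47. In this assay compound 2 `COc1cccc(CNCCCNc2ccnc3cc(Cc4ccc(F)cc4)ccc23)c1O` gives 9.47, and compound 3 `COc1ccc(F)cc1CNCCCNc1ccnc2cc(Cc3ccc(F)cc3)ccc12` gives 9.47. Compound 2 and compound 1 differ by 3,5-dimethylphenyl in place of 4-fluorophenyl on a saturated chain carbon bound to an aromatic carbon; the step is no change at the digits printed from compound 2 to compound 1 (within the scatter). The two cores differ by 5-fluoro-2-methoxyphenyl in place of 2-hydroxy-3-methoxyphenyl on a saturated chain carbon bound to an amine nitrogen, with step no change at the digits printed from compound 2 to compound 3 (within the scatter). Compound 4 `COc1ccc(F)cc1CNCCCNc1ccnc2cc(Cc3cc(C)cc(C)c3)ccc12` has not been measured in this assay; it differs from compound 3 by 3,5-dimethylphenyl in place of 4-fluorophenyl on a saturated chain carbon bound to an aromatic carbon, at the same place as before, so this is the same change. The expected step is no change at the digits printed from compound 3 to compound 4 (within the scatter), because the earlier instance of this change gave no change at the digits printed from compound 2 to compound 1 (within the scatter) and the core swap gave no change at the digits printed from compound 2 to compound 3 (within the scatter). Compound 4 is therefore estimated at 9.47, with a range expected from 9.2 to 9.75.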

Compound 4, acid dissociation constant: 9.47
Beside the measured number, compound 4's estimate shows no gap at the digits printed; the measured number falls inside the stated range.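

In this assay, 3,5-dimethylphenyl in place of 4-fluorophenyl gives no change at the digits printed from compound 3 to compound 4 (within the scatter), as it gave no change at the digits printed from compound 2 to compound 1 (within the scatter) on the other core, and the core swap with 3,5-dimethylphenyl in place gives no change at the digits printed from compound 1 to compound 4 (within the scatter). Across these two cores the change therefore carries over with no readable step, but this does not show that it would stay silent on any other core or in any other read-out. No measurement here bears on why the values stay level.

Still open, from the compounds shown here alone, is whether a carboxylic acid or an amine in place of 3,5-dimethylphenyl would leave the read-out level. The same holds for a longer chain in place of the saturated chain.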